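The source may report more compounds than this note shows. Statements on the series, on what has been measured and on what is new or still open speak of the compounds shown alone.

Working notes on the series. Three measured compounds share the core of compound 1 `O=S(=O)(NCC1CCN(CCCc2c[nH]c3ccc(-n4cnnc4)cc23)CC1)c1ccccc1` and differ only in the group on a saturated ring carbon of the six-membered non-aromatic ring with one nitrogen. In an assay on CHO cells for agonist activity at 5-hydroxytryptamine receptor 1D (Homo sapiens), read by GTPgammaS binding (a lower number here means that less compound is needed, a higher number that more compound is needed for the effect), compound 1 gives 12 nM. Compound 2 `c1ccc2c(c1)CCC2NC1CCN(CCCc2c[nH]c3ccc(-n4cnnc4)cc23)CC1` gives 25 nM in this assay, a step of a 2.1-fold higher number from compound 1 to compound 2 (0.32 log units; beyond the scatter). Compound 3 `OCCC(NC1CCN(CCCc2c[nH]c3ccc(-n4cnnc4)cc23)CC1)c1ccccc1` gives 5.1 nM in this assay and stands lowest of the three: a 2.4-fold lower number from compound 1 to compound 3 (0.37 log units; beyond the scatter), and a 4.9-fold lower number from compound 2 to compound 3 (0.69 log units; beyond the scatter).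

Compound 4 `CN(Cc1ccsc1)C1CCN(CCCc2c[nH]c3ccc(-n4cnnc4)cc23)CC1` awaits measurement. Its change from compound 3 is methyl((thiophen-3-yl)methyl)amino in place of (3-hydroxy-1-phenylpropyl)amino on a saturated ring carbon. All three measured steps vary this same ring position, and each was modest in size; none introduces the entering group, and none removes both the hydroxy group and the phenyl ring at once, so they set only a scale. On that scale a modest step in this assay is expected for compound 4, more likely upward than downward, and is estimated as a 2.4-fold higher number from compound 3 to compound 4 (0.37 log units; beyond the scatter). Compound 4 is therefore expected near 12 nM in this assay, within a range from 4 nM to 40 nM.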

Compound 4, half-maximal effective concentration: 4.2 nM
Beside the measured number, compound 4's estimate is 2.9-fold (0.46 log units) above it, within the range that was stated.
By their numbers in this assay, from the lowest: compounds 4 and 3 (each within the scatter of the next); then compound 1; then compound 2.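

In this assay, the methyl((thiophen-3-yl)methyl)amino group, with 0 hydrogen-bond donors and a five-membered aromatic ring, holds the number level with the (3-hydroxy-1-phenylpropyl)amino group (a 1.2-fold lower number from compound 3 to compound 4 (0.08 log units; within the scatter)). On a saturated ring carbon of this six-membered non-aromatic ring, a number at this level therefore does not depend on the hydroxy group or the six-membered aromatic ring of compound 3, and the new group also stands clear of the two other groups (a 6.0-fold lower number from compound 2 to compound 4 (0.77 log units; beyond the scatter); a 2.9-fold lower number from compound 1 to compound 4 (0.46 log units; beyond the scatter)). No supporting data on this change are available to account for the result.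

Open, as far as these compounds go, is whether the methyl group on the amine nitrogen of compound 4 can give way to hydrogen or to an ethyl group. Also open, from the compounds shown here alone, is whether a furan-3-yl or phenyl ring can stand in place of the thiophen-3-yl ring at the same level.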